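Replacing 3,5-dimethoxyphenyl with 3-aminophenyl

A few compounds are considered here, and "the series" means these few. Any claim that something is new, unique, unknown or untested is made for them only; others in the source may bear on it.

Measured so far in a functional assay on HCT-116 cells (Homo sapiens) for cytotoxicity, read by MTT assay, with a stated time of 72 h; a higher number here means a weaker inhibitor, a lower number a stronger inhibitor
Compound 1 `Cc1ccc(S(=O)(=O)c2nc3ccccc3nc2Nc2cccc(N)c2)cc1` gives 2390 nM
Compound 2 `COc1ccc(S(=O)(=O)c2nc3ccccc3nc2Nc2cc(OC)cc(OC)c2)cc1` gives 13400 nM

Compound 2 (13400 nM) has the higher of the two numbers and is therefore the weaker inhibitor, with compound 1 lying below it by more than the usual scatter. Compound 3 (`COc1ccc(S(=O)(=O)c2nc3ccccc3nc2Nc2cccc(N)c2)cc1`) has not yet been measured. It takes 3-aminophenyl in place of 3,5-dimethoxyphenyl on a nitrogen on an aromatic ring. Within the data shown here, no measured pair isolates this swap, but compound 1 (2390 nM) carries the same 3-aminophenyl, and this supports the expectation of a stronger compound. The expected step is a 4.5-fold lower number from compound 2 to compound 3 (0.65 log units; beyond the scatter) in this assay and points to a lower number, beyond the scatter. For compound 3 the half-maximal inhibitory concentration is estimated at 3000 nM (1200 nM to 7500 nM).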

Compound 3, half-maximal inhibitory concentration: 3710 nM
Beside the measured number, compound 3's estimate is 1.2-fold (0.09 log units) below it; the range from low to high includes it.
By their numbers in this assay, from the lowest: compounds 1 and 3 (each within the scatter of the next); then compound 2.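

In this assay, among these compounds, the swap of 3,5-dimethoxyphenyl for 3-aminophenyl on a nitrogen on an aromatic ring gives a 3.6-fold lower number from compound 2 to compound 3 (0.56 log units; beyond the scatter), the first direct reading of this change with the rest of the structure held fixed. The exchange of methyl for methoxy on an aromatic carbon gives a 1.6-fold higher number from compound 1 to compound 3 (0.19 log units; within the scatter), so in this pair the two groups cannot be told apart in this assay. Nothing available explains either step.

The compounds shown leave open whether the amine itself matters or whether losing the two methoxy groups is enough, which plain phenyl or 3-methoxyphenyl on the same nitrogen could separate. They also leave open how 3-hydroxyphenyl would compare there, and how a chlorine or a fluorine would compare with methyl and methoxy on that aromatic carbon.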